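Swapping the Group on the Oxygen Without a Readable Guide

This account rests on a few compounds, and the source may have more. Where it says the series, first, only, none or still open, it means among the compounds named here.

Compound 3 `CC(C)[C@H](NC(=O)COc1cccc2ccccc12)C(=O)N[C@@H](CC(=O)O)C(=O)COn1nnc2ccccc21` is one of three close relatives that share a common core. In a functional assay on Jurkat cells (Homo sapiens) for inhibition (on this read-out lower numbers stand for stronger inhibition and higher numbers for weaker inhibition), compound 3 gives only a limit, > 200000 nM. Compound 1 `CC(C)[C@H](NC(=O)COc1cccc2ccccc12)C(=O)N[C@@H](CC(=O)O)C(=O)CSc1nc[nH]n1` likewise gives a limit in this assay, > 200000 nM. Compound 2 `CC(C)[C@H](NC(=O)COc1cccc2ccccc12)C(=O)N[C@@H](CC(=O)O)C(=O)CSc1nc2ccccc2o1` also gives a limit in this assay, > 200000 nM. Since all three sit at the limit of > 200000 nM in this assay, at which 3 of the 3 values shown sit, the steps among them cannot be sized: a step that the two limits leave unreadable from compound 1 to compound 2, a step that the two limits leave unreadable from compound 1 to compound 3 and a step that the two limits leave unreadable from compound 2 to compound 3.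

Compound 4 `CC(C)[C@H](NC(=O)COc1cccc2ccccc12)C(=O)N[C@@H](CC(=O)O)C(=O)COc1cncc2ccccc12` differs from compound 3 in one place: a group of 10 heavy atoms (9 carbon, 1 nitrogen; one six-membered aromatic ring of carbon only, one six-membered aromatic ring with 1 hetero atom) in place of a group of 9 heavy atoms (6 carbon, 3 nitrogen; one five-membered aromatic ring with 3 hetero atoms, one six-membered aromatic ring of carbon only), on an oxygen on a saturated carbon. Among the measured compounds shown here, none of the measured steps bears on this change, so neither its size nor its direction can be read from what has been seen. For the measured compounds named here, the only guide is that every relative so far rests at the limit given by the limit of > 200000 nM in this assay, at which 3 of the 3 values shown sit. The step of an at least 1.3-fold lower number from compound 3 to compound 4 (0.12 log units; that floor lies within the scatter) is therefore expected to stay within the scatter, with a fair chance that the result is again a limit. Compound 4 is expected to give about 150000 nM in this assay, within a range from 5000 nM to 1000000 nM.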

Compound 4, half-maximal inhibitory concentration: 166000 nM
Estimate against measurement, compound 4: 1.1-fold (0.04 log units) below; measured number inside the range.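

In this assay, among the compounds shown here, compound 4, with isoquinolin-4-yl on the oxygen, gives 166000 nM, the first actual number rather than a limit. Its comparisons with the earlier compounds are only floors: an at least 1.2-fold lower number from compound 3 to compound 4 (0.08 log units; that floor lies within the scatter), an at least 1.2-fold lower number from compound 2 to compound 4 (0.08 log units; that floor lies within the scatter) and an at least 1.2-fold lower number from compound 1 to compound 4 (0.08 log units; that floor lies within the scatter), so the direction is suggested but no gap beyond the scatter is shown. Compound 1, compound 2 and compound 3 remain at a single limit: the limit of > 200000 nM in this assay, at which 3 of the 4 values shown sit.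

Going by these compounds, the true size of these steps stays open, and with it whether the swap to isoquinolin-4-yl matters at all. Also open, on these data alone, is whether a plain phenyl group on that oxygen, or an amine on the isoquinolin-4-yl, would give a clearly different number in this assay.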